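Replacing cyclopentyl with a hydroxypentyl chain on the amide

The source may report more compounds than this note shows. Statements on the series, on what has been measured and on what is new or still open speak of the compounds shown alone.

Compound 1 `COc1cccc2cc(C(=O)NC3CCCC3)c(=N)oc12` stands at the top of the three numbers recorded in an assay on HeLa cells for displacement of a labelled ligand from adenosine receptor A3 (Homo sapiens), read by scintillation counting, with a stated time of 180 min, tested at 10 uM (a higher number here means more inhibition at the concentration tested (going by the name of the read-out), a lower number less inhibition), where compound 1 gives 20%. Compound 2 `COCCNC(=O)c1cc2cc(Cl)ccc2oc1=N` gives 13% in this assay, a number that lies within the scatter of the value of compound 1, so no order between the two can be claimed. Compound 3 `O=C(O)CNC(=O)c1cc2ccccc2oc1=O` gives 0% in this assay, a number beyond the scatter below compound 1. Going by the values given here, no step between measured compounds that differ in a single place is available, so nothing measured tells how a change at the amide-type nitrogen shifts inhibition.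

Compound 4 `COc1cccc2cc(C(=O)NCCCCCO)c(=N)oc12` is the compound not yet measured. It differs from compound 1 as follows: 5-hydroxypentyl in place of cyclopentyl on an amide-type nitrogen. Among the compounds with values here, with no measured step to guide the size, the account expects a small change from compound 1 to compound 4 in this assay, a number 8 percentage points lower from compound 1 to compound 4 (within the scatter), most likely downward but plausibly within the scatter. Compound 4 is therefore estimated at 12% in this assay, with a range from 0% to 26%.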

Compound 4, a percentage reported as inhibition, at one concentration (the size of the read-out at that concentration, not a potency): 13%
Compound 4: middle estimate off by 1 percentage points, on the low side; measured number inside the range.
By their numbers in this assay, from the lowest: compound 3; then compounds 2, 4 and 1 (each within the scatter of the next).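

Going by these compounds alone, the step from the cyclopentyl amide gives the first single-place reading at this amide-type nitrogen in this assay: a number 7 percentage points lower from compound 1 to compound 4 (within the scatter). Here, 5-hydroxypentyl, which has no ring and brings in a hydrogen-bond donor and acceptor, takes the place of cyclopentyl without a change that can be told from the usual scatter. The ring at this nitrogen is therefore not shown to be needed for the inhibition seen at the concentration tested, and no measurement available here bears on why the two groups read alike.

Going by these compounds, whether any group on this nitrogen can move the number beyond the scatter remains open, for instance a 5-aminopentyl chain or a benzyl group. A reading at one concentration also leaves the potency of both compounds undefined.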